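A few compounds are considered here, and "the series" means these few. Any claim that something is new, unique, unknown or untested is made for them only; others in the source may bear on it.

Measured so far:
compound 1 `O=C(NO)c1ccc(NCc2nc(-c3ccc(Cl)cc3)nn2-c2ccccc2)cc1` — 67.2% in an assay on Sf9 cells for inhibition of protein deacetylase HDAC6 (Homo sapiens), read by fluorescence, with a stated time of 40 min, tested at 100 nM; a lower number here means less inhibition, a higher number more inhibition at the concentration tested (going by the name of the read-out)
compound 2 `O=C(NO)c1ccc(NCc2nc(-c3ccccc3)nn2-c2cccc(Cl)c2)cc1` — 62.3%

Compound 2 stands at the lower of the two numbers in this assay, but its gap to compound 1 is within the scatter, so the two are not told apart. Compound 3 `CCc1ccc(-n2nc(-c3ccccc3)nc2CNc2ccc(C(=O)NO)cc2)cc1` is not yet measured and differs from compound 2 in one place: 4-ethylphenyl in place of 3-chlorophenyl on an aromatic nitrogen. Going by the values given here, no step between measured compounds bears on this change, so the direction is open. The estimated step is a number 4.3 percentage points lower from compound 2 to compound 3 (within the scatter). Compound 3 is expected to give 58%, between 38% and 76%.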

Compound 3, a percentage reported as inhibition, at one concentration (the size of the read-out at that concentration, not a potency): 38.3%
Compound 3: middle estimate off by 19.7 percentage points, on the high side, and the stated range covers the measured number.
By their numbers in this assay, from the lowest: compound 3; then compounds 2 and 1 (each within the scatter of the next).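

This position on the aromatic nitrogen is sensitive to the choice of aryl group: in this assay, 4-ethylphenyl in place of 3-chlorophenyl gives a number 24 percentage points lower from compound 2 to compound 3 (beyond the scatter). The change swaps the substituent and also moves it around the ring, so the step cannot be assigned to either alone. No measurement at hand offers a reason for the step.

Still open, from the compounds shown here alone, is which of the two changes carries the step, a question that 3-ethylphenyl or 4-chlorophenyl on the same nitrogen would address. Also open, going by these compounds, is how an amine or a carboxylic acid on that ring would read.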